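Arylsulfonamide benzylamines: nitro placement on the sulfonyl aryl

A few compounds are considered here, and "the series" means these few. Any claim that something is new, unique, unknown or untested is made for them only; others in the source may bear on it.

Of the compounds shown here, two carry numbers so far. Compound 1 `O=[N+]([O-])c1ccc(S(=O)(=O)NCCCCCCNCc2ccc(Br)cc2)cc1` pairs a 4-nitrophenyl sulfonamide with a bromine-bearing benzylamine through a linker. In a functional assay on MIA PaCa-2 cells (Homo sapiens) for inhibition, read by MTT assay, with a stated time of 72 h (a higher number here means a weaker inhibitor of growth, a lower number a stronger inhibitor of growth), compound 1 gives 9800 nM. Compound 2 `O=S(=O)(NCCCNCc1ccc(-c2ccccc2)cc1)c1cc(C(F)(F)F)cc(C(F)(F)F)c1` uses a different sulfonyl aryl, a shorter linker and a biphenyl benzylamine; in this assay compound 2 gives 2400 nM. Compound 1 therefore stands as the highest of the two numbers, with compound 2 lower by a gap beyond the usual scatter. Compound 1 and compound 2 differ in several places at once. No single structural step can be read from that pair.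

Compound 3 `O=[N+]([O-])c1ccccc1S(=O)(=O)NCCCCCCNCc1ccc(Br)cc1` is the next candidate and is still to be measured. It keeps every atom of compound 1 and differs only in one place: 2-nitrophenyl in place of 4-nitrophenyl on a sulfonyl sulfur. Among the measured compounds shown here, no measured pair isolates 2-nitrophenyl in place of 4-nitrophenyl on a sulfonyl sulfur, so the step of a 1.2-fold lower number from compound 1 to compound 3 (0.06 log units; within the scatter) is expected to be small, likely within the scatter, with no firm direction. Compound 3 is accordingly estimated at 8500 nM in this assay, with a plausible range from 3000 nM to 25000 nM.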

Compound 3, concentration for 50% growth inhibition: 11700 nM
Beside the measured number, compound 3's estimate is 1.4-fold (0.14 log units) below it; measured number inside the range.
By their numbers in this assay, from the lowest: compound 2; then compounds 1 and 3 (each within the scatter of the next).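

In this assay, among the compounds shown here, 2-nitrophenyl in place of 4-nitrophenyl on a sulfonyl sulfur gives a 1.2-fold higher number from compound 1 to compound 3 (0.08 log units; within the scatter), the first step that changes a single place. With the linker and the bromine-bearing benzylamine held fixed, the measurement does not separate 2-nitrophenyl from 4-nitrophenyl at this position, so the nitro placement shows no readable effect on growth inhibition in this pair. No available measurement bears on why the two compounds read alike.

Still open, from the compounds shown here alone, is whether a group other than nitro on the sulfonyl aryl, such as a carboxylic acid or a primary amine, would give a step beyond the scatter from compound 1. Steps for the linker and the benzylamine cannot be read from the compounds shown, so a longer chain as linker, or a chlorine in place of the bromine on the benzylamine, remains an untested single-place change in this series.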